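The source may report more compounds than this note shows. Statements on the series, on what has been measured and on what is new or still open speak of the compounds shown alone.

Three compounds share one core and were all tested in a functional assay on RPMI8266 cells (Homo sapiens) for inhibition, read by sulforhodamine B assay, with a stated time of 48 h; a higher number here means a weaker inhibitor of growth, a lower number a stronger inhibitor of growth. Compound 1 `Nc1cc(N)c2nc(-c3ccccc3)c(NCc3ccc(Cl)c(Cl)c3)nc2c1` gives 1660 nM in this assay. Compound 2 `CCOC(=O)[C@H](CCC(=O)O)NC(=O)c1ccc(Sc2nc3cc(N)cc(N)c3nc2-c2ccccc2)cc1` gives 339 nM in this assay, and compound 3 `COc1cc(CNc2nc3cc(N)cc(N)c3nc2-c2ccccc2)cc(OC)c1OC` gives 692 nM in this assay. For the measured compounds named here, of these three numbers, the one for compound 1 is the highest, so compound 1 is the weakest growth inhibitor of the group; the gaps to compound 3 and to compound 2 both lie beyond the usual scatter. No two of these measured compounds differ in only one place, so no single change can be tied to a measured step.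

Compound 4 `Nc1cc(N)c2nc(-c3ccccc3)c(NCc3ccc(F)cc3)nc2c1` is not yet measured. It differs from compound 1 in one place: 4-fluorophenyl in place of 3,4-dichlorophenyl on a saturated chain carbon bound to a nitrogen on an aromatic ring. Going by the values given here, there is no measured pair to show what such a change does here. The step from compound 1 to compound 4 is expected to be small, a 1.5-fold higher number from compound 1 to compound 4 (0.18 log units; within the scatter), with the number likely staying near that of compound 1 or rising somewhat. For compound 4 the expected value in this assay is 2500 nM, with a range from 900 nM to 7000 nM.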

Compound 4, concentration for 50% growth inhibition: 2510 nM
Compound 4: the middle estimate sits 1.0-fold (0.00 log units) below what was measured; the range from low to high includes it.
By their numbers in this assay, from the lowest: compound 2; then compound 3; then compounds 1 and 4 (each within the scatter of the next).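

For the compounds shown here, this is the first pair here that differs in only one place. In this assay, placing 4-fluorophenyl where 3,4-dichlorophenyl stood, on a saturated chain carbon bound to a nitrogen on an aromatic ring, gives a 1.5-fold higher number from compound 1 to compound 4 (0.18 log units; within the scatter), so this change of halogens on the ring does not measurably alter growth inhibition, and compound 1 and compound 4 cannot be told apart. No evidence is available here to explain this result.

The change removes chlorine and adds fluorine in one step, so the effect of each remains unseparated, and a 4-chlorophenyl group or a plain phenyl group with no halogen would be needed to pull them apart. Also open, on these data alone, is whether the same flat result would hold for a more different group, such as a ring carrying an amine or a carboxylic acid, or for a longer chain.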